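Swapping a Sulfonamide in a Leukotriene Receptor Binder

The compounds below may be only part of what the source reports. "The series", "measured", "known", "first", "only" and "open" are said of these compounds alone.

Of the compounds shown here, three have been measured in an assay for binding affinity to leukotriene B4 receptor 1 (Homo sapiens); a higher number here means a weaker inhibitor, a lower number a stronger inhibitor. Compound 1 `CCCCCCCCCCCCOc1ccc(C[S+]([O-])c2cccc(C(=O)O)c2)nc1/C=C/C(=O)O` gives 129 nM, compound 2 `COc1ccc(CCCCCCCCOc2ccc(C[S+]([O-])c3cccc(NS(=O)(=O)c4ccccc4)c3)nc2/C=C/C(=O)O)cc1` gives 147 nM, and compound 3 `COc1ccc(CCCCCCOc2ccc(CC(O)c3cccc(C(=O)O)c3)nc2/C=C/C(=O)O)cc1` gives 165 nM. Compound 2 sits among the other two on the plain numbers, yet all three lie within the usual scatter of one another, so no order can be drawn from them. Compound 4 `COc1ccc(CCCCCCCCOc2ccc(C[S+]([O-])c3cccc(CS(=O)(=O)C(F)(F)F)c3)nc2/C=C/C(=O)O)cc1` is not yet measured. It differs from compound 2 in one place: ((trifluoromethyl)sulfonyl)methyl in place of (phenylsulfonyl)amino on an aromatic carbon. Within the data shown here, no measured pair shows such a change, so the data give no guide to its size or direction. Compound 4 is expected to give about 200 nM, with a range from 60 nM to 700 nM. The expected step is a 1.4-fold higher number from compound 2 to compound 4 (0.13 log units; within the scatter), likely not beyond the scatter.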

Compound 4, inhibition constant: 225 nM
The estimate for compound 4 lay 1.1-fold (0.05 log units) below the measured number; the measured number falls inside the stated range.
By their numbers in this assay, from the lowest: compounds 1, 2, 3 and 4 (each within the scatter of the next).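

In this assay the swap gives a 1.5-fold higher number from compound 2 to compound 4 (0.18 log units; within the scatter) and so shows that this aromatic carbon can carry either group without a change beyond the scatter. The (phenylsulfonyl)amino group's carbon-only aromatic ring and its hydrogen-bond donor can both be gone, with ((trifluoromethyl)sulfonyl)methyl in their place, and the number still cannot be told apart from that of compound 2. No measurement at hand speaks to why the two groups read alike. As far as these compounds go, what a simple amine or a nitrile would give on this aromatic carbon stays open, as does whether the swap reads the same with a different chain on the shared core.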